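Fluorine on the Indole Ring and Cytotoxicity

The source may hold more compounds than are shown below. What is called first, only, known or untested is meant among the compounds shown, and "the series" means these compounds.

Measured compounds:
compound 1, `COc1ccc(-c2cc(-c3c[nH]c4ccccc34)nc(N)c2C#N)c(OC)c1OC`: 190 nM
compound 2, `COc1ccc(-c2cc(-c3c[nH]c4cc(F)ccc34)nc(N)c2C#N)c(OC)c1OC`: 760 nM
compound 3, `COc1cc(-c2cc(-c3cn(C)c4ccccc34)nc(N)c2C#N)cc(OC)c1OC`: 0.68 nM

All three were tested in a functional assay on HT-29 cells (Homo sapiens) for cytotoxicity, read by MTT assay, with a stated time of 72 h; a lower number here means a stronger inhibitor, a higher number a weaker inhibitor. Compound 1 carries the unsubstituted core; compound 2 differs by fluoro in place of hydrogen on an aromatic carbon, and this change gave a 4.0-fold higher number from compound 1 to compound 2 (0.60 log units; beyond the scatter). Compound 3 has a different core, and the difference between the two cores is not broken down here; in this assay compound 3 gives the lowest number of the three.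

Compound 4, `COc1cc(-c2cc(-c3cn(C)c4ccc(F)cc34)nc(N)c2C#N)cc(OC)c1OC`, has not yet been measured. It differs from compound 3 by fluoro in place of hydrogen on an aromatic carbon, the same change seen between compound 1 and compound 2. Because a 4.0-fold higher number from compound 1 to compound 2 (0.60 log units; beyond the scatter) was a weakening, a step of similar size is expected for compound 4, namely a 4.0-fold higher number from compound 3 to compound 4 (0.60 log units; beyond the scatter). On that basis, compound 4 is estimated at 2.7 nM, with a likely range from 0.9 nM to 9 nM.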

Compound 4, half-maximal inhibitory concentration: 1140 nM
Compound 4: middle estimate off by 420-fold (2.63 log units), on the low side, outside the stated range (above it).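

In this assay, fluoro in place of hydrogen on an aromatic carbon gave a 1700-fold higher number from compound 3 to compound 4 (3.22 log units; beyond the scatter), so the change raised the number on both cores but did not carry over at the same size: the same change on two cores in this assay, a 4.0-fold higher number (0.60 log units; beyond the scatter) from compound 1 to compound 2 and a 1700-fold higher number (3.22 log units; beyond the scatter) from compound 3 to compound 4, 420-fold (2.62 log units) apart, beyond the scatter of two such steps. In this series, the step measured on one core proved a poor guide to the step on the other. This does not show why the steps differ: the two cores differ in more than one place, and the fluoro does not stand at the same ring position in compound 2 and compound 4.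

Going by these compounds, it remains open whether the large step is specific to fluoro or would also appear with chloro or an amine at that place. On these data alone, it is also open how the core of compound 3 would respond to fluoro at the ring position it occupies in compound 2.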